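A few compounds are considered here, and "the series" means these few. Any claim that something is new, unique, unknown or untested is made for them only; others in the source may bear on it.

In a functional assay on MCF7 cells (Homo sapiens) for antiproliferative activity, read by MTT assay (on this read-out lower numbers stand for stronger inhibition and higher numbers for weaker inhibition), compound 3 `CCOC(=O)/C=N/c1cnc(Nc2ccc(S(N)(=O)=O)cc2)nc1NC1CCCC1` gives 42200 nM, the lowest of the two numbers shown in the series. Compound 1 `CCOC(=O)/C=N/c1cnc(Nc2ccc(N3CCN(C)CC3)cc2)nc1NC1CCCC1` gives 42300 nM; the step of a 1.0-fold lower number from compound 1 to compound 3 (0.00 log units; within the scatter) lies within the scatter, so no order between these two is claimed. Compound 2 `CN1CCN(c2ccc(Nc3ncc(/N=C/c4ccccc4)c(NC4CCCC4)n3)cc2)CC1` gives only the limit > 100000 nM, not a number. Compound 4 `NS(=O)(=O)c1ccc(Nc2ncc(/N=C/c3ccc(C(F)(F)F)cc3)c(NC3CCCC3)n2)cc1` differs from compound 3 by 4-(trifluoromethyl)phenyl in place of ethoxycarbonyl on a carbon with a double bond to nitrogen. Among the compounds with values here, the one measured step that bears on this change is an at least 2.3-fold higher number from compound 1 to compound 2 (0.37 log units; beyond the scatter), where a phenyl replaced the same ethoxycarbonyl on the same carbon, and the resulting value sits at the limit of > 100000 nM in this assay, at which 1 of the 3 values shown sits. A weakening of comparable size is therefore expected, a 2.4-fold higher number from compound 3 to compound 4 (0.37 log units; beyond the scatter), and the assay may again report only a limit. Compound 4 is expected at 100000 nM, within 30000 nM to 300000 nM.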

Compound 4, half-maximal inhibitory concentration: > 100000 nM
Compound 4 was reported as a limit (the forecaster's own chance of this, stated with the estimate: 50%); the middle value lies on the limit itself.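

In this assay, the step of an at least 2.3-fold higher number from compound 3 to compound 4 (0.37 log units; beyond the scatter) matches an at least 2.3-fold higher number from compound 1 to compound 2 (0.37 log units; beyond the scatter), so replacing ethoxycarbonyl with an aromatic ring on this carbon weakens the read-out with sulfamoyl as well as with 4-methylpiperazin-1-yl in the other varied place. The full size of the new step cannot be read, as the value for compound 4 is a limit and not a number. The two compounds with an aromatic ring on this carbon share that limit: the limit of > 100000 nM in this assay, at which 2 of the 4 values shown sit.

Still open, on these data alone, is how a carboxylic acid or a short alkyl chain would read in place of ethoxycarbonyl on this carbon.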